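The source may hold more compounds than are shown below. What is called first, only, known or untested is meant among the compounds shown, and "the series" means these compounds.

Compound 1 `CCN(CC)CCn1cnnc1-c1cc(Oc2ccc(NC(=O)Nc3ccccc3C(F)(F)F)cc2F)ccn1` gives 3410 nM in a functional assay on HT-29 cells (Homo sapiens) for antiproliferative activity, read by MTT assay, with a stated time of 72 h; a lower number here means a stronger inhibitor, a higher number a weaker inhibitor. Compound 2 `CCN(CC)CCn1cnnc1-c1cc(Oc2ccc(NC(=O)Nc3ccc(F)c(F)c3)cc2F)ccn1` gives 1240 nM in this assay. Compound 3 `CCN(CC)CCn1cnnc1-c1cc(Oc2ccc(NC(=O)Nc3ccc(Cl)cc3Cl)cc2F)ccn1` gives 3590 nM in this assay.

Compound 3 has the highest number of the three. Its gap from compound 1, a 1.1-fold higher number from compound 1 to compound 3 (0.02 log units; within the scatter), lies within the scatter, so those two cannot be placed in order. Its gap from compound 2, a 2.9-fold higher number from compound 2 to compound 3 (0.46 log units; beyond the scatter), is beyond the scatter, as is the step of a 2.8-fold lower number from compound 1 to compound 2 (0.44 log units; beyond the scatter). All three of these measured steps change only the aryl group on the urea nitrogen; the rest of the shared core is constant across them.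

Compound 4 `CN(C)CCCn1cnnc1-c1cc(Oc2ccc(NC(=O)Nc3ccc(Cl)cc3Cl)cc2F)ccn1` differs from compound 3 in a different part of the molecule: (dimethylamino)methyl in place of diethylamino on a saturated chain carbon, two bonds along the chain from an aromatic nitrogen. The urea part of compound 4 is that of compound 3. For the measured compounds named here, no measured pair varies this side chain, so the three steps on hand bear on it only indirectly, by showing that the aryl urea is where the measured differences have come from. With nothing measured at this position, the working expectation is that the change produces no step beyond the scatter. Compound 4 is therefore expected to give about 3600 nM in this assay, with a range from 1500 nM to 8500 nM. That estimate corresponds to an expected step of a 1.0-fold higher number from compound 3 to compound 4 (0.00 log units; within the scatter), within the scatter.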

Compound 4, half-maximal inhibitory concentration: 680 nM
Estimate against measurement, compound 4: 5.3-fold (0.72 log units) above; measured number below the stated range.
By their numbers in this assay, from the lowest: compounds 4 and 2 (each within the scatter of the next); then compounds 1 and 3 (each within the scatter of the next).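

The side chain is not a silent position: with the urea part held as in compound 3, replacing 2-(diethylamino)ethyl with 3-(dimethylamino)propyl gives a 5.3-fold lower number from compound 3 to compound 4 (0.72 log units; beyond the scatter) in this assay. For the compounds shown here, the earlier steps all changed the aryl group on the urea nitrogen, so this is the first sign that the number also responds to a change away from that aryl group, here on the chain carried by the aromatic nitrogen. No measurement given here accounts for the step, so its origin remains unexplained.

This single step changes the chain and the alkyl groups on its amine together, so the compounds shown do not tell which of the two carries it; 2-(dimethylamino)ethyl and 3-(diethylamino)propyl on the same 2,4-dichlorophenyl urea would separate them, and a cyclic amine such as 3-(morpholin-4-yl)propyl would test whether an open dialkylamine is needed at all. They also leave open whether the step carries over to other aryl ureas, such as the 3,4-difluorophenyl urea of compound 2, or is tied to the 2,4-dichlorophenyl group.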